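Swapping the sulfonyl side chain for a phenyl ring

The source may hold more compounds than are shown below. What is called first, only, known or untested is meant among the compounds shown, and "the series" means these compounds.

Measured so far in a physicochemical assay for permeability, using PAMPA, at pH 7.4; on this read-out higher numbers stand for higher permeability and lower numbers for lower permeability:
Compound 1 `CC(C)(C)OC(=O)NCCS(=O)(=O)NC(=O)c1ccc(Nc2nc(NC3(c4ccc(Cl)cc4)CC3)nc(OCC(F)(F)F)n2)cc1` gives 111 nm/s.
Compound 2 `O=C(NS(=O)(=O)CCNC(=O)C1CC1)c1ccc(Nc2nc(NC3(c4ccc(Cl)cc4)CC3)nc(OCC(F)(F)F)n2)cc1` gives 1 nm/s.

Compound 2 stands at the lowest of the two numbers; its nearest neighbour is compound 1, reached by a 110-fold lower number from compound 1 to compound 2 (2.05 log units; beyond the scatter). Compound 3 `O=C(NS(=O)(=O)c1ccccc1)c1ccc(Nc2nc(NC3(c4ccc(Cl)cc4)CC3)nc(OCC(F)(F)F)n2)cc1` is not yet measured. It differs from compound 2 in one place: phenyl in place of 2-((cyclopropylcarbonyl)amino)ethyl on a sulfonyl sulfur. Among the measured compounds shown here, the only measured step, a 110-fold lower number from compound 1 to compound 2 (2.05 log units; beyond the scatter), changes a different place, the group on the carbonyl carbon, and so bears on this step only loosely; it shows that changes in this side chain can move this assay a long way. For compound 3 a rise in this assay is expected, since the chain with one hydrogen-bond donor and one acceptor leaves and a bare phenyl enters, giving a 30-fold higher number from compound 2 to compound 3 (1.48 log units; beyond the scatter) as the expected step. The estimate for compound 3 is 30 nm/s, with a range from 4 nm/s to 200 nm/s.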

Compound 3, apparent permeability: 182 nm/s
The estimate for compound 3 lay 6.1-fold (0.78 log units) below the measured number; the range from low to high includes it.
By their numbers in this assay, from the lowest: compound 2; then compounds 1 and 3 (each within the scatter of the next).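

At the sulfonyl sulfur, phenyl in place of 2-((cyclopropylcarbonyl)amino)ethyl gives a 180-fold higher number from compound 2 to compound 3 (2.26 log units; beyond the scatter) in this assay, so the low reading of compound 2 is not fixed by the shared core or by this position. Phenyl and 2-((tert-butoxycarbonyl)amino)ethyl, two very different groups on that sulfur, cannot be told apart here, with a 1.6-fold higher number from compound 1 to compound 3 (0.21 log units; within the scatter). Nothing available explains why the cyclopropyl-capped chain stands so far from both.

The compounds shown leave open how a chain ending in a free amine, or a phenyl ring carrying a carboxylic acid, would read in this assay. A plain methyl on the sulfonyl sulfur would also help show whether a ring is needed at all for a reading like that of compound 3.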